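Benzyl to (thiophen-2-yl)methyl exchange on the shared core

This account rests on a few compounds, and the source may have more. Where it says the series, first, only, none or still open, it means among the compounds named here.

Compound 3 `CCn1c(=O)c2c(nc(Cc3ccccc3)n2C)n(Cc2ccco2)c1=O` gives 28.8 nM in an assay on cell membranes for displacement of a labelled ligand from adenosine receptor A1 (Rattus norvegicus) (a higher number here means a weaker inhibitor, a lower number a stronger inhibitor), the lowest number among the three measured compounds: compound 1 `CCCn1c(=O)c2[nH]c(Cc3ccccc3)nc2n(Cc2ccco2)c1=O` gives 302 nM and compound 2 `CCCCCn1c(=O)c2[nH]c(Cc3ccccc3)nc2n(Cc2ccco2)c1=O` gives 871 nM. For the measured compounds named here, the only measured step, a 2.9-fold higher number from compound 1 to compound 2 (0.46 log units; beyond the scatter), concerns the chain and says nothing about the phenyl. Compound 4 `CCn1c(=O)c2c(nc(Cc3cccs3)n2C)n(Cc2ccco2)c1=O` differs from compound 3 by thiophen-2-yl in place of phenyl on a saturated chain carbon bound to an aromatic carbon. Going by the values given here, no measured pair in this set bears on that exchange, so the expectation rests on compound 3 alone, and the step of a 1.0-fold higher number from compound 3 to compound 4 (0.02 log units; within the scatter) is expected to stay within the scatter in either direction. Compound 4 is therefore estimated at 30 nM in this assay, with a range from 10 nM to 90 nM.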

Compound 4, inhibition constant: 102 nM
Estimate against measurement, compound 4: 3.4-fold (0.53 log units) below; the whole stated range lies below it.
By their numbers in this assay, from the lowest: compound 3; then compound 4; then compound 1; then compound 2.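

Unlike the earlier chain step, this is a change on the saturated chain carbon bound to an aromatic carbon, and there the aromatic ring is not freely exchangeable: in this assay, thiophen-2-yl in place of phenyl gives a 3.5-fold higher number from compound 3 to compound 4 (0.55 log units; beyond the scatter) and the change is not neutral. Phenyl is the better of the two rings on this core. Nothing available explains the step.

From the compounds shown here alone, whether cyclohexyl or a pyridine ring at this place would match phenyl remains open. So does whether the exchange has the same size on the core of compound 1.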